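Methyl in place of hydrogen on the indole-type nitrogen

A few compounds are considered here, and "the series" means these few. Any claim that something is new, unique, unknown or untested is made for them only; others in the source may bear on it.

Measured compounds:
compound 1 `COc1cc(/C=C/c2ccc3c(ccn3S(=O)(=O)c3ccccc3)c2)cc(OC)c1OC`: > 5000 nM
compound 2 `COc1cc(/C=C/c2ccc3[nH]ccc3c2)cc(OC)c1OC`: 250 nM
compound 3 `COc1cc(/C=C\c2ccc3[nH]ccc3c2)cc(OC)c1OC`: 34 nM

The account follows the step from compound 2 to compound 4. In a functional assay on HeLa cells (Homo sapiens) for inhibition (a higher number here means a weaker inhibitor, a lower number a stronger inhibitor), compound 2 gives 250 nM. Among the numbers shown, compound 2 has the highest one; its nearest neighbour is compound 3, which gives 34 nM in this assay, so that a 7.4-fold lower number from compound 2 to compound 3 (0.87 log units; beyond the scatter), a change that rests on (the fact that compounds 2 and 3 differ only in the configuration as drawn). For compound 1 the result in this assay is a limit of the assay and not a number, > 5000 nM. Compound 4 `COc1cc(/C=C/c2ccc3c(ccn3C)c2)cc(OC)c1OC` has not yet been measured in this assay. methyl in place of hydrogen on an aromatic nitrogen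

The measured step that bears on this change is the one at the same place: an at least 20-fold lower number from compound 1 to compound 2 (1.30 log units; beyond the scatter), a step anchored in the limit of > 5000 nM in this assay, at which 1 of the 3 values shown sits. That step replaced a phenylsulfonyl, a much larger group than a methyl, so its full size need not carry over; the direction it points, however, is toward a higher number when the hydrogen on that nitrogen is replaced. Compound 4 is therefore expected to give a somewhat higher number than compound 2, an expected step of a 1.8-fold higher number from compound 2 to compound 4 (0.26 log units; within the scatter), though well short of the limit seen for compound 1. The estimate for compound 4 in this assay is 450 nM, with a range from 120 nM to 2000 nM.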

Compound 4, half-maximal inhibitory concentration: 24 nM
Compound 4: the middle estimate sits 19-fold (1.27 log units) above what was measured, outside the stated range (below it).
By their numbers in this assay, from the lowest: compounds 4 and 3 (each within the scatter of the next); then compound 2. At a limit, above all of these: compound 1.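

Compound 4 shows that a substituent on the aromatic nitrogen of the five-membered ring need not raise the number in this assay: methyl in place of hydrogen gives a 10-fold lower number from compound 2 to compound 4 (1.02 log units; beyond the scatter). The earlier compounds had shown only phenylsulfonyl at this place, and methyl in place of that group gives an at least 200-fold lower number from compound 1 to compound 4 (2.31 log units; beyond the scatter), so what enters matters and not merely the loss of the hydrogen. The size of that last step is open-ended, as the result for compound 1 is a limit of the assay and not a number: the limit of > 5000 nM in this assay, at which 1 of the 4 values shown sits.

The compounds shown leave open whether methyl on this nitrogen would act in the same way on the Z double bond of compound 3, as the methyl step is known only with the double bond drawn E. They also leave open where the trend between hydrogen, methyl and phenylsulfonyl turns, for instance with ethyl, a longer chain, or a chain ending in an amine or a carboxylic acid on the same nitrogen.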